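A few compounds are considered here, and "the series" means these few. Any claim that something is new, unique, unknown or untested is made for them only; others in the source may bear on it.

Measured compounds:
Compound 1, `N#C/N=C(\NCCCCc1ccccc1)NCCCc1c[nH]cn1`: 5.03 in an in vitro functional assay on Sf9 cells for antagonist activity at histamine H2 receptor (Homo sapiens); on this read-out higher numbers stand for higher potency (the scale is a negative logarithm) and lower numbers for lower potency
Compound 2, `N#C/N=C(/NCCCc1c[nH]cn1)NCCC(c1ccccc1)c1ccccc1`: in this assay compound 2 gives only a limit, < 5
Compound 3, `N#C/N=C(\NCCCCc1ccccc1)NCCCCc1c[nH]cn1`: 5.03 in this assay

Compound 3 stands level with compound 1 at the digits shown. The one step measured among these compounds, no change at the digits printed from compound 1 to compound 3 (within the scatter), lengthened the chain on the imidazole side and moved the number by nothing beyond the scatter. Among the compounds with values here, the remaining value shown is a limit, (the limit of < 5 in this assay, at which 1 of the 3 values shown sits), and gives no size for any step.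

Compound 4, `N#C/N=C(/NCCCCc1c[nH]cn1)NCCCc1ccccn1`, differs from compound 3 by pyridin-2-yl in place of benzyl on a saturated chain carbon, three bonds along the chain from an amine nitrogen. No measured step bears on this change: the single step shown concerns the other end of the molecule, and the limit for compound 2 sets no size. The expectation therefore rests on compound 3 alone, and the step from compound 3 to compound 4 is estimated as a number 0.03 log units lower from compound 3 to compound 4 (within the scatter), that is, no change beyond the scatter. For compound 4 the value in this assay is estimated at 5, with a range from 4.5 to 5.6.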

Compound 4, negative logarithm of the antagonist equilibrium constant: 5.48
The estimate for compound 4 lay 0.48 log units below the measured number; measured number inside the range.
By their numbers in this assay, from the lowest: compounds 1 and 3 (each within the scatter of the next); then compound 4. At a limit, below all of these: compound 2.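

In this assay the far end of the molecule responds where the imidazole side did not: pyridin-2-yl in place of benzyl, on a saturated chain carbon, three bonds along the chain from an amine nitrogen, gives a number 0.45 log units higher from compound 3 to compound 4 (beyond the scatter) while the earlier lengthening on the imidazole side gave no change at the digits printed from compound 1 to compound 3 (within the scatter) at the digits shown. This is the only step shown that lies beyond the scatter, and the entering group brings one ring nitrogen and one hydrogen-bond acceptor where benzyl has neither. Nothing measured here separates that ring nitrogen from the change in the link to the ring, and no measurement shown gives a reason for the step.

As far as these compounds go, how pyridin-3-yl or pyridin-4-yl would read at this place remains open, as does the effect of a longer chain carrying the pyridin-2-yl group. Also open, from the compounds shown here alone, is whether the same change gives a similar step on the shorter imidazole-side chain of compound 1.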